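Adding a Methoxy Group to Compound 3

This account rests on a few compounds, and the source may have more. Where it says the series, first, only, none or still open, it means among the compounds named here.

Measured in a functional assay on SiHa cells (Homo sapiens) for inhibition, read by sulforhodamine B assay; a lower number here means a stronger inhibitor of growth, a higher number a weaker inhibitor of growth:
- compound 1 `COc1cc(-c2ccc(-c3ccc(-c4nc5cc(C)ccc5[nH]4)cc3)cc2)cc(OC)c1OC`: 170 nM
- compound 2 `COc1cc(-c2ccc(-c3ccc(-c4nc5ccccc5[nH]4)cc3)cc2)cc(OC)c1OC`: 4980 nM
- compound 3 `COc1ccc(-c2ccc(-c3ccc(-c4nc5c(O)cccc5[nH]4)cc3)cc2)cc1OC`: 1110 nM

Compound 3 stands in the middle of these three, with a lower number than compound 2 and a higher one than compound 1. Compound 4 `COc1cc(-c2ccc(-c3ccc(-c4nc5c(O)cccc5[nH]4)cc3)cc2)cc(OC)c1OC` differs from it by one change, methoxy in place of hydrogen on an aromatic carbon. Going by the values given here, no measured pair shows this same change. Among the compounds with values here, the only measured step, a 29-fold higher number from compound 1 to compound 2 (1.47 log units; beyond the scatter), swaps a different group, so it gives no direction here. It does show that one small change can shift the number widely, which calls for a broad range. The expected step is modest, a 1.2-fold lower number from compound 3 to compound 4 (0.09 log units; within the scatter). The estimate for compound 4 is 900 nM, with an expected range of 200 nM to 4000 nM.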

Compound 4, concentration for 50% growth inhibition: 170 nM
Beside the measured number, compound 4's estimate is 5.3-fold (0.72 log units) above it; the measured number lies below the stated range.
By their numbers in this assay, from the lowest: compounds 1 and 4 (each within the scatter of the next); then compound 3; then compound 2.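

Methoxy in place of hydrogen, ortho to a methoxy group, brings a 6.5-fold lower number from compound 3 to compound 4 (0.81 log units; beyond the scatter) and so shows that this position responds to the change. Hydroxy in place of hydrogen gives a 29-fold lower number from compound 2 to compound 4 (1.47 log units; beyond the scatter) and thus matters as much as the methyl group does. With 4-hydroxy-1H-benzimidazol-2-yl in place of 5-methyl-1H-benzimidazol-2-yl there is no change at the digits printed from compound 1 to compound 4 (within the scatter) and the two groups cannot be told apart here.

On these data alone, whether an ethoxy group or an amine at this position would serve as well remains open. Nothing available here explains these steps.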